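This account rests on a few compounds, and the source may have more. Where it says the series, first, only, none or still open, it means among the compounds named here.

Values so far in a physicochemical assay for solubility, read by HPLC, in phosphate buffer, measured as kinetic solubility, at pH 7.4; a higher number here means a more soluble compound, a lower number a less soluble compound
Compound 1 `CCC(=O)c1cc(-c2ccccc2)n(-c2ccc(S(N)(=O)=O)cc2)c1C` gives 14100 nM
Compound 2 `CCC(=O)c1cc(-c2ccc(C)cc2)n(-c2ccc(S(N)(=O)=O)cc2)c1C` gives 1000 nM
Compound 3 `CCC(=O)c1cc(-c2ccccc2Cl)n(-c2ccc(S(N)(=O)=O)cc2)c1C` gives 38200 nM

Compound 1 stands second highest of the three numbers (14100 nM), with compound 3 above it and compound 2 below it. Compound 4 `CCCc1cc(-c2ccccc2)n(-c2ccc(S(N)(=O)=O)cc2)c1C` remains unmeasured. It differs from compound 1 by one change (propyl in place of propanoyl on an aromatic carbon), propyl in place of propanoyl on an aromatic carbon of the shared core.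

Going by the values given here, no measured step touches that place. All three alter the phenyl group instead. Methyl in place of hydrogen gave a 14-fold lower number from compound 1 to compound 2 (1.15 log units; beyond the scatter) and chloro in place of hydrogen gave a 2.7-fold higher number from compound 1 to compound 3 (0.43 log units; beyond the scatter), while the swap of the two substituted phenyl groups gave a 38-fold higher number from compound 2 to compound 3 (1.58 log units; beyond the scatter). These steps point in both directions, so they fix no direction for the new change, but they show that one small change in this set can move the number far.

A lower number is expected, since the group that enters has no hydrogen-bond acceptor, and the size is taken as moderate to large, guided loosely by the step of a 14-fold lower number from compound 1 to compound 2 (1.15 log units; beyond the scatter) as the nearest all-carbon addition. The estimated change is a 3.5-fold lower number from compound 1 to compound 4 (0.55 log units; beyond the scatter) in this direction. Compound 4 is expected at 4000 nM (estimated range 800 nM to 16000 nM).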

Compound 4, solubility: 3800 nM
The estimate for compound 4 lay 1.1-fold (0.02 log units) above the measured number; the range from low to high includes it.
By their numbers in this assay, from the lowest: compound 2; then compound 4; then compound 1; then compound 3.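

Going by these compounds alone, the earlier steps all altered the phenyl group, so this is the first reading at the aromatic carbon of the five-membered ring that bears the propanoyl group. In this assay, propyl in place of propanoyl gave a 3.7-fold lower number from compound 1 to compound 4 (0.57 log units; beyond the scatter), which shows that the number responds to a change at this place on the shared core as well, and that the step lies beyond the scatter. No measurement shown accounts for the step.

One pair cannot separate the part played by the carbonyl from that of the chain as a whole, and the compounds shown offer no other group here, such as an amine, a carboxylic acid or a longer chain. On these data alone, it also remains open whether the step would keep its direction and size with the 4-methylphenyl group of compound 2 or the 2-chlorophenyl group of compound 3.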